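Solubility of a Fourth Analogue Predicted From Three

A few compounds are considered here, and "the series" means these few. Any claim that something is new, unique, unknown or untested is made for them only; others in the source may bear on it.

Compound 1, `COc1cccc(Oc2ccc3c(NCCCNCc4cccc(OC)c4O)ccnc3c2)c1`: 14500 nM
Compound 2, `COc1cccc(CNCCCNc2ccnc3cc(-c4cccc5ccccc45)ccc23)c1O`: 32000 nM
Compound 3, `COc1cccc(CNCCCNc2ccnc3cc(Cc4cccc(C(F)(F)F)c4)ccc23)c1O`: 4200 nM

The three measured compounds share one core and differ only in the group carried on an aromatic carbon of that core. In a physicochemical assay for solubility, with a stated time of 18 h, at pH 7.4 (on this read-out lower numbers stand for lower solubility and higher numbers for higher solubility), compound 3 stands lowest of the three; the nearest number belongs to compound 1, as a 3.5-fold lower number from compound 1 to compound 3 (0.54 log units; beyond the scatter) shows, and the furthest to compound 2, as a 7.6-fold lower number from compound 2 to compound 3 (0.88 log units; beyond the scatter) shows. Between compound 1 and compound 2 the gap was a 2.2-fold higher number from compound 1 to compound 2 (0.34 log units; beyond the scatter).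

Compound 4, `COc1ccccc1Oc1ccc2c(NCCCNCc3cccc(OC)c3O)ccnc2c1`, is not yet measured. 2-methoxyphenoxy in place of 3-(trifluoromethyl)benzyl on an aromatic carbon The step that bears most directly on it is a 3.5-fold lower number from compound 1 to compound 3 (0.54 log units; beyond the scatter), since compound 1 carries 3-methoxyphenoxy at the same aromatic carbon and the change from compound 3 to compound 4 runs in the opposite direction, restoring a methoxyphenoxy group. For the measured compounds named here, no measured step separates 2-methoxyphenoxy from 3-methoxyphenoxy, so the expectation is anchored on compound 1 and its value 14500 nM.

He therefore expects a modest rise, a 3.1-fold higher number from compound 3 to compound 4 (0.49 log units; beyond the scatter), in this assay. For compound 4 the estimated solubility is 13000 nM, with a range from 5500 nM to 30000 nM.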

Compound 4, solubility: 14500 nM
Beside the measured number, compound 4's estimate is 1.1-fold (0.05 log units) below it; low and high end bracket the measured number.
By their numbers in this assay, from the lowest: compound 3; then compounds 1 and 4 (each within the scatter of the next); then compound 2.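

In this assay, for the compounds shown here, 2-methoxyphenyl in place of 3-methoxyphenyl on the oxygen gives no change at the digits printed from compound 1 to compound 4 (within the scatter) and so, unlike the earlier steps, shows a change within the phenoxy substituent that leaves the number within the scatter. Setting 2-methoxyphenoxy on the aromatic carbon in place of 3-(trifluoromethyl)benzyl gives a 3.5-fold higher number from compound 3 to compound 4 (0.54 log units; beyond the scatter) in this read-out, matching in size a 3.5-fold lower number from compound 1 to compound 3 (0.54 log units; beyond the scatter) in the opposite direction, while setting it in place of naphthalen-1-yl gives a 2.2-fold lower number from compound 2 to compound 4 (0.34 log units; beyond the scatter) and so matches a 2.2-fold higher number from compound 1 to compound 2 (0.34 log units; beyond the scatter) in size, again in the opposite direction. Among these four compounds, the two methoxyphenoxy compounds therefore stand together, with compound 3 on one side of them and compound 2 on the other.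

Nothing given here offers a measured account of why these groups separate as they do. Also open, on these data alone, is whether an unsubstituted phenoxy group, an amine or a carboxylic acid on the same aromatic carbon would stay with the methoxyphenoxy pair, or whether the same match would hold with a longer chain in the core.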